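The compounds below may be only part of what the source reports. "The series", "measured", "known", "first", "only" and "open" are said of these compounds alone.

In a physicochemical assay for lipophilicity, measured as octanol-water partition (a lower number here means a more polar compound, a higher number a more lipophilic compound), three compounds sharing one core have been measured. Compound 1 `COC(=O)c1cn(C/C=C(/C)CC/C=C(\C)CCC=C(C)C)nn1` gives 5.25 in this measure, compound 2 `CCCCCc1cn(C/C=C(/C)CC/C=C(\C)CCC=C(C)C)nn1` gives 7.5 and compound 3 `CCCCCCCCc1cn(C/C=C(/C)CC/C=C(\C)CCC=C(C)C)nn1` gives 8.76 as the highest of the three numbers. Compound 4 `CCCCCCCCc1cn(C/C=C(\C)CC/C=C(\C)CCC=C(C)C)nn1` is the next to be measured, and its relation to compound 3 is simple: the two compounds have the same atoms and bonds and differ only in configuration as drawn: 1 of 2 stereo elements differ; a double bond is drawn Z in compound 3 and E in compound 4 and no group leaves or enters. Each measured step replaces a group, with a number 2.25 log units higher from compound 1 to compound 2 (beyond the scatter) for pentyl in place of methoxycarbonyl, a number 3.51 log units higher from compound 1 to compound 3 (beyond the scatter) for octyl in place of methoxycarbonyl and a number 1.26 log units higher from compound 2 to compound 3 (beyond the scatter) for propyl in place of hydrogen on a saturated chain carbon. For the measured compounds named here, all three are large, but none of them changes only the configuration of a double bond, so the data offer no direct precedent. The atoms and bonds stay the same, and the estimated step is no change at the digits printed from compound 3 to compound 4 (within the scatter) with no change beyond the scatter expected. For compound 4 the expected value is 8.76 with an estimated range from 8.4 to 9.1 when it is measured.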

Compound 4, partition coefficient: 8.76
Estimate against measurement, compound 4: no gap at the digits printed; low and high end bracket the measured number.
By their numbers in this assay, from the lowest: compound 1; then compound 2; then compounds 3 and 4 (each within the scatter of the next).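

In this assay, redrawing one double bond from Z to E with the octyl group in place gives no change at the digits printed from compound 3 to compound 4 (within the scatter). For the compounds shown here, every earlier step replaced a group and lay beyond the scatter, whereas this is the first step that alters configuration alone, and it stays within the scatter. The comparison is a clean one, with nothing leaving or entering: the fact that compounds 3 and 4 differ only in the configuration as drawn.

The compounds shown leave open whether the same redrawing would also stay within the scatter with pentyl or methoxycarbonyl on the shared core, or at the second double bond, which is drawn alike in this pair. They also leave open how a carboxylic acid or an amine in place of octyl would read in this assay, with either configuration of the double bond.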